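Quinone for hydroquinone on a second pyrazole core

The source may report more compounds than this note shows. Statements on the series, on what has been measured and on what is new or still open speak of the compounds shown alone.

Compound 1 `Oc1ccc(O)c(-c2cc(-c3ccc(Cl)cc3)nn2-c2ccccc2)c1` and compound 3 `O=C1C=CC(=O)C(c2cc(-c3ccc(Cl)cc3)nn2-c2ccccc2)=C1` share one core and differ in a single place. In a functional assay on cells (Cancer cell lines, Homo sapiens) for cytotoxicity, read by sulforhodamine B assay, with a stated time of 48 h (a higher number here means a weaker inhibitor of growth, a lower number a stronger inhibitor of growth), compound 1 gives 16800 nM, and compound 3 gives 69700 nM. The change between them is a group of 8 heavy atoms (6 carbon, 2 oxygen; one six-membered non-aromatic ring of carbon only) in place of a group of 8 heavy atoms (6 carbon, 2 oxygen; one six-membered aromatic ring of carbon only), on an aromatic carbon and the step it made is a 4.1-fold higher number from compound 1 to compound 3 (0.62 log units; beyond the scatter).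

Compound 2 `CC(=O)NS(=O)(=O)c1ccc(-n2nc(-c3ccccc3)cc2-c2cc(O)ccc2O)cc1` carries a different core; how the two cores differ is not broken down here. In this assay compound 2 gives 100000 nM, which stands highest of the three measured numbers, near the number for compound 3 and well apart from the number for compound 1.

Compound 4 `CC(=O)NS(=O)(=O)c1ccc(-n2nc(-c3ccccc3)cc2C2=CC(=O)C=CC2=O)cc1` is the unmeasured partner of compound 2. The change from compound 2 to compound 4 is a group of 8 heavy atoms (6 carbon, 2 oxygen; one six-membered non-aromatic ring of carbon only) in place of a group of 8 heavy atoms (6 carbon, 2 oxygen; one six-membered aromatic ring of carbon only), on an aromatic carbon. Among the measured compounds shown here, it is the same kind of change as the one from compound 1 to compound 3, though the surroundings differ: in compound 1 the changed carbon sits next to the ring atom that bears a phenyl group and two ring bonds from the ring atom that bears a 4-chlorophenyl group, whereas in compound 2 it sits next to the ring atom that bears a large group and two ring bonds from the ring atom that bears a phenyl group.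

The step from compound 2 to compound 4 in this assay is expected to be a 1.6-fold higher number from compound 2 to compound 4 (0.20 log units; within the scatter), resting on compound 1 and compound 3, whose step was a 4.1-fold higher number from compound 1 to compound 3 (0.62 log units; beyond the scatter). Because compound 2 already gives 100000 nM, the number for compound 4 may exceed what the assay can report. Compound 4 is estimated at 160000 nM, expected between 60000 nM and 500000 nM.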

Compound 4, concentration for total growth inhibition: 100000 nM
Compound 4: the middle estimate sits 1.6-fold (0.20 log units) above what was measured; measured number inside the range.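

On the core of compound 2, the change from 2,5-dihydroxyphenyl to the quinone gives, in this assay, no change at the digits printed from compound 2 to compound 4 (within the scatter). Set beside the core of compound 1, the same change does not carry over at the same size: the same change on two cores in this assay, a 4.1-fold higher number (0.62 log units; beyond the scatter) from compound 1 to compound 3 and no change at the digits printed (within the scatter) from compound 2 to compound 4, 4.1-fold (0.62 log units) apart, beyond the scatter of two such steps

This rests on one pair per core, so it shows that the step is not a fixed increment across these two cores, but it does not show which difference between the cores matters, and those differences are not separated here into single changes. Compound 2 and compound 4 also print the same high number, and nothing shown tells whether that number is a true reading or the top of what this assay can report, so the flat step may not be a measure of the true difference.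

Open, from the compounds shown here alone, is how the step behaves on the core of compound 2 with a 4-chlorophenyl group in place of its phenyl group, which would test that one difference on its own. Also open, going by these compounds, is whether a carboxylic acid in place of the acetylated sulfonamide, or methoxy groups in place of the hydroxyls of the 2,5-dihydroxyphenyl group, would bring the numbers into a range where the step can be read.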